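The compounds below may be only part of what the source reports. "The series", "measured", "known", "first", "only" and "open" are said of these compounds alone.

The three measured compounds:
Compound 1, `CN1C(=O)[C@@]2(c3ccccc31)N(C)C[C@@H](c1ccco1)[C@@]21Cc2ccccc2C1=O`; in a functional assay on the whole organism (strain Wister albino) for inhibition, with Rattus norvegicus as the target, read by paw edema, with a stated time of 1 h, at a dose of 50 mg/kg by the intraperitoneal route (a higher number here means more inhibition at the dose given (going by the name of the read-out), a lower number less inhibition), compound 1 gives 50.1%.
Compound 2, `CN1C(=O)[C@@]2(c3ccccc31)N(C)C[C@@H](c1ccc(F)cc1)[C@@]21Cc2ccccc2C1=O`; in this assay compound 2 gives 52.9%.
Compound 3, `Cc1ccc([C@@H]2CN(C)[C@]3(C(=O)N(C)c4ccccc43)[C@]23Cc2ccccc2C3=O)cc1`; in this assay compound 3 gives 46.9%.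

Compound 1 stands second highest of the three numbers, with compound 2 nearest and compound 3 furthest; the steps of a number 2.8 percentage points higher from compound 1 to compound 2 (within the scatter) and a number 3.2 percentage points lower from compound 1 to compound 3 (within the scatter) both lie within the scatter, as does a number 6 percentage points lower from compound 2 to compound 3 (within the scatter). Compound 4, `CN1C[C@@H](c2ccco2)[C@@]2(Cc3ccccc3C2=O)[C@@]12C(=O)Nc1ccccc12`, differs from compound 1 by hydrogen in place of methyl on an amide-type nitrogen in a ring. Among the measured compounds shown here, none of the measured steps touches the amide-type nitrogen in a ring; each exchanges only the group on a saturated ring carbon, and each stays within the scatter. For the measured compounds named here, no measured step therefore bears directly on this change, and the set as a whole shows only small movements. Compound 4 is consequently expected to sit close to compound 1, with a step of a number 2.1 percentage points lower from compound 1 to compound 4 (within the scatter) that is not expected to exceed the scatter. The estimate for compound 4 is 48%, within 35% to 61%.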

Compound 4, a percentage reported as inhibition, in the whole organism at one dose (the size of the read-out at that dose, not a potency): 48.8%
Estimate against measurement, compound 4: 0.8 percentage points below; the measured number falls inside the stated range.
By their numbers in this assay, from the lowest: compounds 3, 4, 1 and 2 (each within the scatter of the next).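

Compound 4 is the first of the compounds shown to change the amide-type nitrogen in a ring rather than the group on a saturated ring carbon, and in this assay it gives a number 1.3 percentage points lower from compound 1 to compound 4 (within the scatter) at this single dose. Methyl at this position can therefore give way to hydrogen with the number staying within the scatter. No evidence on the cause of this result is available. On these data alone, it remains open whether a longer chain, such as benzyl, on this nitrogen would shift the number. Also open, as far as these compounds go, is whether hydrogen here behaves alike with 4-fluorophenyl in place of furan-2-yl.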